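This account rests on a few compounds, and the source may have more. Where it says the series, first, only, none or still open, it means among the compounds named here.

Compound 1 `COc1cc(-c2nnc3n2NC(c2cccs2)C(C(=O)c2ccccc2)S3)cc(OC)c1OC` is one of three analogues sharing the same core and trimethoxyphenyl substituent, differing in the groups on the saturated ring carbon and on the carbonyl carbon. In a functional assay on A549 cells (Homo sapiens) for cytotoxicity, read by MTT assay, with a stated time of 48 h (a lower number here means a stronger inhibitor, a higher number a weaker inhibitor), compound 1 gives 69400 nM. Compound 2 `COc1cc(-c2nnc3n2NC(c2ccco2)C(C(=O)c2ccco2)S3)cc(OC)c1OC` gives 68700 nM in this assay, and the two numbers lie within the scatter of each other, so compound 1 stands highest of the two numbers only nominally. Compound 3 `COc1cccc(C(=O)C2Sc3nnc(-c4cc(OC)c(OC)c(OC)c4)n3NC2c2ccco2)c1` reaches only a limit in this assay, > 100000 nM, which is the limit of > 100000 nM in this assay, at which 1 of the 3 values shown sits. For the measured compounds named here, the single step with a number, an at least 1.4-fold higher number from compound 2 to compound 3 (0.16 log units; that floor lies within the scatter), shows that a 3-methoxyphenyl in place of furan-2-yl on the carbonyl carbon did not produce a measurable gain.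

Compound 4 `COc1cc(-c2nnc3n2NC(c2ccco2)C(C(=O)c2ccccc2)S3)cc(OC)c1OC` differs from compound 1 by furan-2-yl in place of thiophen-2-yl on a saturated ring carbon. Going by the values given here, no measured step covers this exchange directly. Compound 2, which already carries furan-2-yl at that position, gives 68700 nM, essentially the same as compound 1, so the expected step of a 1.1-fold higher number from compound 1 to compound 4 (0.03 log units; within the scatter) is none beyond the scatter. Compound 4 is therefore estimated at 75000 nM, with a range from 35000 nM to 160000 nM.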

Compound 4, half-maximal inhibitory concentration: 33400 nM
The estimate for compound 4 lay 2.2-fold (0.35 log units) above the measured number; measured number below the stated range.
By their numbers in this assay, from the lowest: compound 4; then compounds 2 and 1 (each within the scatter of the next). At a limit, above all of these: compound 3.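

For the compounds shown here, the exchange on the saturated ring carbon, which no earlier step covered, has a measurable effect in this assay: with the benzoyl group kept, furan-2-yl in place of thiophen-2-yl gives a 2.1-fold lower number from compound 1 to compound 4 (0.32 log units; beyond the scatter). With furan-2-yl on the saturated ring carbon, the group on the carbonyl carbon also counts: phenyl in place of furan-2-yl gives a 2.1-fold lower number from compound 2 to compound 4 (0.31 log units; beyond the scatter), while hydrogen in place of methoxy on an aromatic carbon of the benzoyl group gives an at least 2.9-fold lower number from compound 3 to compound 4 (0.47 log units; beyond the scatter). Compound 3 stands at a limit of the assay, not at a number: the limit of > 100000 nM in this assay, at which 1 of the 4 values shown sits.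

The compounds shown leave open whether an amine or a carboxylic acid on the benzoyl group, or a longer chain in place of furan-2-yl on the saturated ring carbon, would shift the number further. They also give no cause for any of these steps.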